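A few compounds are considered here, and "the series" means these few. Any claim that something is new, unique, unknown or untested is made for them only; others in the source may bear on it.

In a functional assay on MCF7 cells (Homo sapiens) for antiproliferative activity, read by CellTiter-Glo, with a stated time of 5 days (on this read-out higher numbers stand for weaker inhibition and lower numbers for stronger inhibition), compound 3 `O=C(O)/C=C/c1ccc(/C(=C(\c2ccc(F)cc2Cl)C2CCC2)c2ccc(-c3cncs3)cc2)cc1` gives 4.2 nM. Within the data shown here, this is the middle of the three numbers so far, since compound 1 `N#Cc1ccc(/C(=C(\c2ccc(/C=C/C(=O)O)cc2)c2ccc3scnc3c2)C2CCC2)c(Cl)c1` gives 1.4 nM and compound 2 `N#Cc1ccc(/C(=C(\c2ccc(/C=C/C(=O)O)cc2)c2ccc3nccn3c2)C2CCC2)c(Cl)c1` gives 15 nM, and the gaps to both lie beyond the scatter. Compound 4 `N#Cc1ccc(/C(=C(\c2ccc(/C=C/C(=O)O)cc2)c2ccc(-c3cncs3)cc2)C2CCC2)c(Cl)c1` keeps the rest of compound 3 but has cyano in place of fluoro on an aromatic carbon, turning 2-chloro-4-fluorophenyl into 2-chloro-4-cyanophenyl: cyano in place of fluoro on an aromatic carbon. Among the measured compounds shown here, no measured step makes this swap. For the measured compounds named here, the only measured step, an 11-fold higher number from compound 1 to compound 2 (1.03 log units; beyond the scatter), is large but changes a different part of the molecule, and both of its compounds carry the 2-chloro-4-cyanophenyl group. Compounds with that group therefore fall on either side of compound 3, so the data point in no clear direction. The expected change is an estimated 1.2-fold lower number from compound 3 to compound 4 (0.08 log units; within the scatter), which would not clearly exceed the scatter. For compound 4 the estimated value is 3.5 nM, with an expected range from 1.2 nM to 10 nM.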

Compound 4, half-maximal inhibitory concentration: 2.9 nM
The estimate for compound 4 lay 1.2-fold (0.08 log units) above the measured number; the range from low to high includes it.
By their numbers in this assay, from the lowest: compound 1; then compounds 4 and 3 (each within the scatter of the next); then compound 2.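

In this assay the swap of fluoro for cyano at this position, para to a large group, gives a 1.4-fold lower number from compound 3 to compound 4 (0.16 log units; within the scatter) and stays within the scatter, so this pair does not separate the 2-chloro-4-fluorophenyl and 2-chloro-4-cyanophenyl groups. With the 2-chloro-4-cyanophenyl group shared, changing the other aromatic group does move the number, with a 5.2-fold lower number from compound 2 to compound 4 (0.71 log units; beyond the scatter) and a 2.1-fold higher number from compound 1 to compound 4 (0.32 log units; beyond the scatter) both beyond the scatter. Nothing measured here gives a reason for any of these steps.

The compounds shown compare only fluoro and cyano at this position, so whether a methoxy group or an amine there would also leave the number in place remains open. From the compounds shown here alone, whether the same swap would behave alike with 1,3-benzothiazol-5-yl in place of 4-(1,3-thiazol-5-yl)phenyl also remains open.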